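The compounds below may be only part of what the source reports. "The series", "measured", "known", "first", "only" and "open" are said of these compounds alone.

Compound 1, `COc1ccc(-n2nc(Sc3ccc(Cl)cc3)cc(CC[C@@H](C)NC(=O)[C@H]3CNCC[C@@H]3c3cccc(Cl)c3)c2=O)cc1`, gives 43 nM in an assay on CHO cells for binding affinity to Melanocortin receptor 4 (Homo sapiens); on this read-out higher numbers stand for weaker inhibition and lower numbers for stronger inhibition.
Compound 2, `COc1ccc(-n2nc(Sc3ccc(Cl)cc3)cc(CC[C@@H](C)NC(=O)[C@H]3CCNC[C@@H]3c3ccc(Cl)cc3Cl)c2=O)cc1`, gives 36 nM in this assay.
Compound 3, `COc1ccc(-n2nc(Sc3ccc(Cl)cc3)cc(CC[C@@H](C)NC(=O)[C@H]3CCNC[C@@H]3c3ccc(F)cc3)c2=O)cc1`, gives 66 nM in this assay.

All three share the same core and differ only in the aryl group attached to a saturated ring carbon. For the measured compounds named here, compound 3 has the highest number of the three, but its gaps to compound 1 and to compound 2 lie within the scatter, so no order among them can be read from these values; the one step that is directly comparable, a 1.8-fold higher number from compound 2 to compound 3 (0.26 log units; within the scatter), is also within the scatter.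

Compound 4, `COc1ccc(-n2nc(Sc3ccc(Cl)cc3)cc(CC[C@@H](C)NC(=O)[C@H]3CCNC[C@@H]3c3ccc(C#N)cc3)c2=O)cc1`, is the next compound. It differs from compound 3 by cyano in place of fluoro on an aromatic carbon. Going by the values given here, the only measured step that bears on it is the aryl swap from compound 2 to compound 3, which stayed within the scatter, and that swap touched a different position on the same ring. On this basis a step of a 1.1-fold lower number from compound 3 to compound 4 (0.04 log units; within the scatter) in this assay is expected, with no change beyond the scatter. Compound 4 is therefore estimated at 60 nM, in a range from 20 nM to 180 nM.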

Compound 4, half-maximal inhibitory concentration: 45 nM
The estimate for compound 4 lay 1.3-fold (0.12 log units) above the measured number, and the stated range covers the measured number.
By their numbers in this assay, from the lowest: compounds 2, 1, 4 and 3 (each within the scatter of the next).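

The aromatic carbon para to a large group now carries a second kind of substituent, and in this assay the change from fluoro to cyano gives a 1.5-fold lower number from compound 3 to compound 4 (0.17 log units; within the scatter). This adds a nitrile with one hydrogen-bond acceptor and one more heavy atom, yet the number does not move beyond the scatter. Replacing the whole aryl group gives the same kind of result, with a 1.3-fold higher number from compound 2 to compound 4 (0.10 log units; within the scatter), and no measurement here offers an explanation for either step.

The compounds shown do not say whether an amine, a carboxylic acid or a longer chain such as n-butyl on this aromatic carbon would shift the number beyond the scatter. For the compounds shown here, with every step so far inside the scatter, they also leave open how much this position matters in this assay.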